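A few compounds are considered here, and "the series" means these few. Any claim that something is new, unique, unknown or untested is made for them only; others in the source may bear on it.

Measured in a functional assay on MCF7 cells (Homo sapiens) for inhibition, read by MTT assay, with a stated time of 72 h; a lower number here means a stronger inhibitor, a higher number a weaker inhibitor:
- compound 1 `Cc1ccc(C(C)C)c(OCc2cn(-c3ccc(O)cc3)nn2)c1`: 45400 nM
- compound 2 `Cc1ccc(C(C)C)c(OCc2cn(-c3cccc(Cl)c3)nn2)c1`: 32100 nM

Within the data shown here, compound 2 stands within the scatter of compound 1, the only other compound measured. Compound 3 `COc1ccc(-n2cc(COc3cc(C)ccc3C(C)C)nn2)cc1` has not yet been measured. It carries 4-methoxyphenyl in place of 3-chlorophenyl on an aromatic nitrogen. Among the measured compounds shown here, one measured step bears on this, also a change of the group on an aromatic nitrogen: a 1.4-fold lower number from compound 1 to compound 2 (0.15 log units; within the scatter). A step beyond the scatter is therefore not expected in this assay. The expected step is a 1.2-fold higher number from compound 2 to compound 3 (0.07 log units; within the scatter). For compound 3 the estimated value is 38000 nM, with an expected range of 18000 nM to 80000 nM.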

Compound 3, half-maximal inhibitory concentration: 25400 nM
Beside the measured number, compound 3's estimate is 1.5-fold (0.17 log units) above it; measured number inside the range.
By their numbers in this assay, from the lowest: compounds 3, 2 and 1 (each within the scatter of the next).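

In this assay, 4-methoxyphenyl in place of 3-chlorophenyl on the aromatic nitrogen gives a 1.3-fold lower number from compound 2 to compound 3 (0.10 log units; within the scatter) and so adds a second change at this position that stays within the scatter. Methyl in place of hydrogen on the oxygen on the aromatic ring gives a 1.8-fold lower number from compound 1 to compound 3 (0.25 log units; within the scatter) and also stays within the scatter, so the three aryl groups on this nitrogen are not told apart here. Nothing available accounts for these small steps.

Going by these compounds, whether a carboxylic acid or an amine on this phenyl ring, or a longer chain in its place, would move the number beyond the scatter remains open.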